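Triazole-Linked Biotin Mimics: Aryl Switch to Trifluoromethylphenyl

The compounds below may be only part of what the source reports. "The series", "measured", "known", "first", "only" and "open" are said of these compounds alone.

Compound 1 `O=C1N[C@H]2[C@H](CS[C@H]2CCCCCc2cn(Cc3ccccc3O)nn2)N1`: in an assay on isolated protein for inhibition of biotin--protein ligase (Homo sapiens), read by scintillation counting, with a stated time of 10 min (a lower number here means a stronger inhibitor, a higher number a weaker inhibitor), compound 1 gives > 16000 nM, a limit of the assay.
Compound 2 `O=C1N[C@H]2[C@H](CS[C@H]2CCCCCc2cn(Cc3cccc(O)c3)nn2)N1`: in this assay compound 2 gives > 16000 nM, also a limit.
Compound 3 `Nc1ccccc1Cn1cc(CCCCC[C@@H]2SC[C@@H]3NC(=O)N[C@@H]32)nn1`: in this assay compound 3 gives > 16000 nM, again a limit.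

Compound 3 therefore stands nowhere on a numerical scale; it sits with the other two at the limit described by the limit of > 16000 nM in this assay, at which 3 of the 3 values shown sit. The steps a step that the two limits leave unreadable from compound 1 to compound 2, a step that the two limits leave unreadable from compound 1 to compound 3 and a step that the two limits leave unreadable from compound 2 to compound 3 are all unreadable in size. Compound 4 `O=C1N[C@H]2[C@H](CS[C@H]2CCCCCc2cn(Cc3ccc(C(F)(F)F)cc3)nn2)N1` carries the change (4-(trifluoromethyl)phenyl in place of 2-aminophenyl on a saturated chain carbon bound to an aromatic nitrogen). Within the data shown here, no measured step bears on this change, so no size or direction beyond the scatter can be expected from the data. Compound 4 is expected to give about 20000 nM in this assay, with a range from 5000 nM to 100000 nM. The expected step that the limit leaves unreadable from compound 3 to compound 4 is most likely itself hidden by a limit.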

Compound 4, inhibition constant: > 16000 nM
Compound 4: a limit, no number (the forecaster's own chance of this, stated with the estimate: 75%); the middle value lies beyond the limit too.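

No step from compound 1, compound 2 or compound 3 to compound 4 can be read in this assay, and all four results are limits, not numbers: the limit of > 16000 nM in this assay, at which 4 of the 4 values shown sit.

The compounds shown leave open whether these groups on the shared core differ at all in strength of inhibition.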